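Amide variation on the pyrrolidinyl-pyrrolidine aniline series

A few compounds are considered here, and "the series" means these few. Any claim that something is new, unique, unknown or untested is made for them only; others in the source may bear on it.

Three compounds of the series have numbers in an assay on CHO cells for displacement of a labelled ligand from histamine receptor H3 (Macaca mulatta); on this read-out lower numbers stand for stronger inhibition and higher numbers for weaker inhibition. Compound 1 `CC1CCCN1C1CCN(c2ccc(NC(=O)C3CCCO3)cc2)C1` gives 8.7 nM, compound 2 `Cc1cc(NC(=O)C2CCCO2)ccc1N1CCC(N2CCCC2C)C1` gives 17 nM, and compound 3 `CC1CCCN1C1CCN(c2ccc(NC(=O)C3CC3)c(C(F)(F)F)c2)C1` gives 14.7 nM. Compound 2 carries the highest of the three numbers, but its gap to compound 3 and to compound 1 is each within the scatter, so no order among the three can be read. Among the measured compounds shown here, the one single-point step available, a 2.0-fold higher number from compound 1 to compound 2 (0.29 log units; within the scatter), is also within the scatter.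

Compound 4 `Cc1cc(NC(=O)CC2CCCC2)ccc1N1CCC(N2CCCC2C)C1` differs from compound 2 in one place: cyclopentylmethyl in place of oxolan-2-yl on a carbonyl carbon. For the measured compounds named here, no measured step changes the group on the carbonyl carbon, so there is nothing to lean on for this change; the pair of compound 2 and compound 3 differs in more than one place and shows only two values within the scatter of each other. Absent any guiding step, the expected outcome is a step no larger than the scatter, a 1.2-fold higher number from compound 2 to compound 4 (0.07 log units; within the scatter). Compound 4 is accordingly estimated at 20 nM in this assay, with a range from 7 nM to 60 nM.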

Compound 4, inhibition constant: 10.7 nM
Compound 4: middle estimate off by 1.9-fold (0.27 log units), on the high side, within the range that was stated.
By their numbers in this assay, from the lowest: compounds 1, 4, 3 and 2 (each within the scatter of the next).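

In this assay, the group on the carbonyl carbon now has its first single-point step: a 1.6-fold lower number from compound 2 to compound 4 (0.20 log units; within the scatter). The change swaps the ring oxygen of oxolan-2-yl, the one hydrogen-bond acceptor counted in that group, for an all-carbon ring with one more heavy atom, and for this pair the number stays within the scatter, so the position tolerates both groups on this read-out. No supporting evidence bears on this step, and no reason for its size can be given.

On these data alone, what an amine or a carboxylic acid on this carbonyl carbon would do to the number remains open, as does the effect of a longer chain. Also open, as far as these compounds go, is whether the same change reads alike on the core of compound 1, which has hydrogen in place of the aromatic methyl.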